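Moving the carboxylic acid on a receptor modulator series

The source may report more compounds than this note shows. Statements on the series, on what has been measured and on what is new or still open speak of the compounds shown alone.

Of the compounds shown here, three sharing one core have been measured in an assay on HEK293 cells for positive allosteric modulation of metabotropic glutamate receptor 2 (Rattus norvegicus), read by thallium flux, with a stated time of 2.5 min; a lower number here means a smaller maximal response, a higher number a larger maximal response. Compound 1 `Cc1c(OCCCCOc2ccccc2C(=O)O)ccc(C(=O)CC2CCCC2)c1C` gives 67.1%, the lowest of the three numbers. Compound 3 `Cc1c(OCCCCOc2ccccc2C(=O)O)ccc(C(=O)CC(C)C)c1C` gives 76.2% in this assay, and compound 2 `CCCC(=O)c1ccc(OCCCCOc2ccc(C(=O)O)cc2C)c(C)c1O` gives 79.3%. Among the measured compounds shown here, the only step between two compounds that differ in a single place runs a number 9.1 percentage points higher from compound 1 to compound 3 (within the scatter). The gap from compound 1 to compound 2 is beyond the scatter, but those two compounds differ in more than one place, so it cannot be tied to any one change.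

Compound 4 `Cc1c(OCCCCOc2cccc(C(=O)O)c2)ccc(C(=O)CC2CCCC2)c1C` has not yet been measured. It keeps every atom of compound 1 but joins them differently: 3-carboxyphenyl in place of 2-carboxyphenyl on an oxygen on a saturated carbon. For the measured compounds named here, none of the measured steps touches the carboxyphenyl group, so there is no direct guide to how moving the acid changes the maximal response. Going by the values given here, the single step that exists concerns the group bound to the carbonyl carbon and is within the scatter. With no evidence for a change in either direction, compound 4 is expected to stay near compound 1, an estimated step of a number 2.9 percentage points higher from compound 1 to compound 4 (within the scatter). The estimate for compound 4 in this assay is 70%, within a range from 55% to 85%.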

Compound 4, largest response reached (reported as percent of maximum), in percent of the reference or control that the assay uses: 22.4%
Estimate against measurement, compound 4: 47.6 percentage points above, and the stated range ends above it.
By their numbers in this assay, from the lowest: compound 4; then compounds 1, 3 and 2 (each within the scatter of the next, the first and the last beyond it).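

In this assay, among the compounds shown here, the place of the carboxylic acid on the ring carries far more weight than anything the earlier compounds showed: 3-carboxyphenyl in place of 2-carboxyphenyl gives a number 44.7 percentage points lower from compound 1 to compound 4 (beyond the scatter), even though the two compounds contain the same atoms, joined differently. For the compounds shown here, the only earlier step between compounds differing in one place, a number 9.1 percentage points higher from compound 1 to compound 3 (within the scatter), changed the group bound to the carbonyl carbon, so this is the first single change to move the maximal response beyond the scatter, and the 2-carboxyphenyl arrangement of compound 1 now stands out as one that this series does not tolerate losing. Nothing shown here offers a measured explanation for the size of this loss.

From the compounds shown here alone, it remains open whether the loss would be the same with the isopropyl group of compound 3 in place of the cyclopentyl group of compound 1. Going by these compounds, it also remains open whether the response depends on the carboxylic acid itself, which a methyl ester or an amide in its place on the 2-carboxyphenyl group could test.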